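This account rests on a few compounds, and the source may have more. Where it says the series, first, only, none or still open, it means among the compounds named here.

Measured in a functional assay on the whole organism (Tail, strain ICR) with Mus musculus as the target, in the tail flick test, with a stated time of 150 min, at a dose of 25 umol/kg by the oral route (a higher number here means a stronger effect of the compound at the dose given, a lower number a weaker effect), so far:
compound 1 `O=C(OCc1ccccc1)[C@@H]1CCCN1C(=O)CN(c1nc(Cl)nc2[nH]cnc12)C1CC1` gives 31.1%;
compound 2 `NCCCC[C@H](NC(=O)CN(c1nc(Cl)nc2[nH]cnc12)C1CC1)C(=O)OCc1ccccc1` gives 9.88%;
compound 3 `NCCCC[C@H](NC(=O)CN(c1nc(Cl)nc2[nH]cnc12)C1CC1)C(=O)O` gives 11.6%.

Compound 2 holds the lowest of the three numbers, though its nearest neighbour, compound 3, lies within the scatter of it, so the two cannot be ordered; only compound 1 stands beyond the scatter above compound 2. Among the measured compounds shown here, the one measured step, a number 1.7 percentage points higher from compound 2 to compound 3 (within the scatter), concerns a different part of the molecule and does not bear on the side chain. Compound 4 `O=C(CN(c1nc(Cl)nc2[nH]cnc12)C1CC1)N[C@@H](CO)C(=O)OCc1ccccc1` differs from compound 2 by hydroxy in place of 3-aminopropyl on a saturated chain carbon, two bonds along the chain from an amide-type nitrogen and a carbonyl carbon. For the measured compounds named here, no measured step tests this change, so nothing points in either direction, and no step beyond the scatter is expected: a number 4.1 percentage points higher from compound 2 to compound 4 (within the scatter) is the working assumption. Compound 4 is accordingly estimated at 14%, within a range of 2% to 32%.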

Compound 4, a percentage reported as activity, at one dose (the size of the read-out at that dose, not a potency): 27.9%
The estimate for compound 4 lay 13.9 percentage points below the measured number; low and high end bracket the measured number.
By their numbers in this assay, from the lowest: compounds 2 and 3 (each within the scatter of the next); then compounds 4 and 1 (each within the scatter of the next).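

In this assay, this saturated chain carbon responds to the change: hydroxy in place of 3-aminopropyl gives a number 18 percentage points higher from compound 2 to compound 4 (beyond the scatter). The only earlier step, a number 1.7 percentage points higher from compound 2 to compound 3 (within the scatter), involved the benzyl ester, so the side chain is the first site in the series shown to move the read-out beyond the scatter. Nothing measured here accounts for this step.

The change removes the amine and shortens the chain together, so the compounds shown do not separate the two. From the compounds shown here alone, whether a plain butyl chain, which carries no amine, would behave like 4-aminobutyl or like hydroxymethyl remains open.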